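Swapping Fluoro for Methoxy on an Indole Cytotoxicity Series

A few compounds are considered here, and "the series" means these few. Any claim that something is new, unique, unknown or untested is made for them only; others in the source may bear on it.

Of the compounds shown here, three sharing a core have been tested in a functional assay on MIA PaCa-2 cells (Homo sapiens) for cytotoxicity, read by WST assay, with a stated time of 48 h; on this read-out higher numbers stand for weaker inhibition and lower numbers for stronger inhibition. Compound 1 `COc1ccc2[nH]cc(/C=C(\C#N)C(=O)c3c[nH]c4cc(F)ccc34)c2c1` gives > 50000 nM, which is a limit of the assay and not a number (the limit of > 50000 nM in this assay, at which 1 of the 3 values shown sits). Compound 2 `N#C/C(=C\c1cn(Cc2ccc(Cl)cc2)c2ccccc12)C(=O)c1c[nH]c2cc(F)ccc12` gives 16600 nM, and compound 3 `COc1ccc2c(C(=O)/C(C#N)=C/c3cn(Cc4ccc(Cl)cc4)c4ccccc34)c[nH]c2c1` gives 40400 nM. The difference between the cores of compound 1 and compound 2 is not broken down here. Compound 3 carries methoxy in place of fluoro on an aromatic carbon relative to compound 2, and this change gave a 2.4-fold higher number from compound 2 to compound 3 (0.39 log units; beyond the scatter). The unmeasured compound 4 `COc1ccc2c(C(=O)/C(C#N)=C/c3c[nH]c4ccc(OC)cc34)c[nH]c2c1` carries the same change relative to compound 1, namely (methoxy in place of fluoro on an aromatic carbon). Compound 4 is expected to give 120000 nM, since the same change produced a 2.4-fold higher number from compound 2 to compound 3 (0.39 log units; beyond the scatter). That estimate means a step that the limit leaves unreadable from compound 1 to compound 4, and it rests on the limit recorded for compound 1 (the limit of > 50000 nM in this assay, at which 1 of the 3 values shown sits), so most likely only a limit will again be reported.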

Compound 4, half-maximal inhibitory concentration: > 50000 nM
Compound 4: only a limit was reported; the forecaster's own chance of this, stated with the estimate: 85%; the middle value lies beyond the limit too.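

Compound 1 and compound 4 both stop at a limit of the assay and not at a number, so no step can be read between them: the limit of > 50000 nM in this assay, at which 2 of the 4 values shown sit.

On these data alone, whether methoxy in place of fluoro changes the number on the core of compound 1 stays open.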